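This account rests on a few compounds, and the source may have more. Where it says the series, first, only, none or still open, it means among the compounds named here.

Compound 1 `Cc1ccccc1-n1nncc1CN1C(=O)C2(C(C#N)=C(N)Oc3c(N)cc4nc5ccccc5nc4c32)c2ccccc21` — > 50000 nM
Compound 2 `N#CC1=C(N)Oc2c(N)cc3nc4ccccc4nc3c2C12C(=O)N(Cc1cnnn1-c1c(F)cccc1F)c1ccccc12` — > 50000 nM

Both measured compounds share one core and differ only in the aryl group carried on the triazole nitrogen. In a functional assay on HCT-116 cells (Homo sapiens) for antiproliferative activity, read by MTT assay, with a stated time of 48 h (a higher number here means a weaker inhibitor, a lower number a stronger inhibitor), compound 1 gives > 50000 nM, which is a limit of the assay and not a number. In the same assay compound 2 also gives > 50000 nM, again a limit. The step that the two limits leave unreadable from compound 1 to compound 2 is therefore unreadable: two limits bound nothing between them. Where compound 2 stands is thus known only as a limit, and the single piece of evidence is the limit of > 50000 nM in this assay, at which 2 of the 2 values shown sit.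

Compound 3 `N#CC1=C(N)Oc2c(N)cc3nc4ccccc4nc3c2C12C(=O)N(Cc1cnnn1-c1ccc(Cl)cc1Cl)c1ccccc12` is the next member. The change from compound 2 is 2,4-dichlorophenyl in place of 2,6-difluorophenyl on an aromatic nitrogen. Among the compounds with values here, no measured step bears on this change in a readable way, because the limit of > 50000 nM in this assay, at which 2 of the 2 values shown sit, is all that the two earlier compounds show. Both aryl variants so far were without measurable effect, so compound 3 is expected to behave alike and to stay at or beyond the limit, giving an estimate of 80000 nM with a range from 30000 nM to 300000 nM. This estimate for compound 3 means an expected step that the limit leaves unreadable from compound 2 to compound 3.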

Compound 3, half-maximal inhibitory concentration: > 50000 nM
Compound 3: a limit, no number (the forecaster's own chance of this, stated with the estimate: 80%); the middle value is on the limit's open side.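

No step can be read between compound 1, compound 2 and compound 3, since each gives a limit of the assay and not a number: the limit of > 50000 nM in this assay, at which 3 of the 3 values shown sit.

The compounds shown leave open how strongly any of them acts in this assay, and whether the 2-methylphenyl, 2,6-difluorophenyl and 2,4-dichlorophenyl groups differ from one another there at all.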